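This account rests on a few compounds, and the source may have more. Where it says the series, first, only, none or still open, it means among the compounds named here.

In a functional assay on MCF7 cells (Homo sapiens) for antiproliferative activity, read by sulforhodamine B assay, with a stated time of 48 h (on this read-out higher numbers stand for weaker inhibition and lower numbers for stronger inhibition), compound 3 `CCN1CCN(c2ccc(S(=O)(=O)Oc3cccc(OC)c3)cc2)C1=O` gives 14000 nM, the higher of the two true numbers, while compound 1 `COc1cccc(OS(=O)(=O)c2ccc(N3CCN(C)C3=O)cc2)c1` gives 3000 nM. Compound 2 `CN1CCN(c2ccc(S(=O)(=O)Oc3cccc([N+](=O)[O-])c3)cc2)C1=O` reads > 100000 nM, which is a limit of the assay. Compound 4 `CCN1CCN(c2ccc(S(=O)(=O)Oc3cccc(Br)c3)cc2)C1=O` carries bromo in place of methoxy on an aromatic carbon of compound 3, meta to a large group: bromo in place of methoxy on an aromatic carbon. The nearest measured change of that methoxy is an at least 33-fold higher number from compound 1 to compound 2 (1.52 log units; beyond the scatter), a large step with nitro entering. The other step, a 4.7-fold higher number from compound 1 to compound 3 (0.67 log units; beyond the scatter), is modest and lies elsewhere on the molecule. With bromo entering, a modest rise in this assay is expected, smaller than the nitro step. The expected step is a 1.8-fold higher number from compound 3 to compound 4 (0.25 log units; within the scatter). For compound 4 the estimate is 25000 nM, with a range of 7000 nM to 90000 nM.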

Compound 4, half-maximal inhibitory concentration: 2500 nM
For compound 4 the middle estimate is 10-fold (1.00 log units) above the measured one; the whole stated range lies above it.
By their numbers in this assay, from the lowest: compounds 4 and 1 (each within the scatter of the next); then compound 3. At a limit, above all of these: compound 2.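

Replacing methoxy on this aromatic carbon need not raise the number in this assay: the change from 3-methoxyphenyl to 3-bromophenyl gives a 5.6-fold lower number from compound 3 to compound 4 (0.75 log units; beyond the scatter). Among the steps shown, this is the only one toward stronger inhibition, so this position can move in either direction depending on the group that enters. Nothing at hand gives a cause for this step. Going by these compounds, it remains open whether bromo has a similar effect on the core of compound 1. Also open, on these data alone, is how an amine, a carboxylic acid or chloro on this aromatic carbon would read.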